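Swapping a Bromine for a Nitro Group on the Benzyl Ether

The source may hold more compounds than are shown below. What is called first, only, known or untested is meant among the compounds shown, and "the series" means these compounds.

Compound 1, `COc1ccc2c(=O)c(-c3cc(OC)c(OC)cc3OC)coc2c1`: 2640 nM
Compound 2, `COc1cc(OC)c(-c2coc3cc(OCc4ccc(Br)cc4)ccc3c2=O)cc1OC`: 1000 nM

Both compounds were tested in a functional assay on A-375 cells (Homo sapiens) for antiproliferative activity, read by MTT assay, with a stated time of 24 h; on this read-out lower numbers stand for stronger inhibition and higher numbers for weaker inhibition. Compound 1 stands highest of the two numbers, with compound 2 as its nearest neighbour. Within the data shown here, the single measured step, a 2.6-fold lower number from compound 1 to compound 2 (0.42 log units; beyond the scatter), is the only one that bears on the change considered here.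

Compound 3, `COc1cc(OC)c(-c2coc3cc(OCc4ccc([N+](=O)[O-])cc4)ccc3c2=O)cc1OC`, differs from compound 1 by 4-nitrophenyl in place of hydrogen on a saturated chain carbon bound to an oxygen on an aromatic ring. Compound 2 carries 4-bromophenyl on a saturated chain carbon bound to an oxygen on an aromatic ring, so the comparison is close: a different six-membered aromatic ring is attached at the same kind of carbon. Because a 2.6-fold lower number from compound 1 to compound 2 (0.42 log units; beyond the scatter) was modest and beyond the scatter, a step of similar size and direction is expected in this assay, namely a 2.4-fold lower number from compound 1 to compound 3 (0.38 log units; beyond the scatter). Compound 3 is therefore estimated at 1100 nM, within a range from 450 nM to 2700 nM.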

Compound 3, half-maximal inhibitory concentration: > 10000 nM
Compound 3 was reported as a limit (the forecaster's own chance of this, stated with the estimate: 3%); middle value at least 9.0-fold (0.95 log units) away from the limit.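

Compound 3 is reported only as a limit, not as a number: the limit of > 10000 nM in this assay, at which 1 of the 3 values shown sits.

Placing 4-nitrophenyl on the saturated chain carbon bound to an oxygen on an aromatic ring gives an at least 3.7-fold higher number from compound 1 to compound 3 (0.57 log units; beyond the scatter), a step in the opposite direction to the one seen with 4-bromophenyl. Nitro in place of bromo on an aromatic carbon gives an at least 10-fold higher number from compound 2 to compound 3 (1.00 log units; beyond the scatter), so among these three compounds, adding an aromatic ring at this place does not by itself lower the number, and the direction of the step depends on what that ring carries.

From the compounds shown here alone, whether an amine or a carboxylic acid in that same place on the ring would behave like bromo or like nitro stays open. Going by these compounds, how far the true value of compound 3 lies beyond its limit also stays open.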